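The source may hold more compounds than are shown below. What is called first, only, known or untested is meant among the compounds shown, and "the series" means these compounds.

In a toxicity assay on Vero cells (Chlorocebus sabaeus) for cytotoxicity (on this read-out lower numbers stand for higher toxicity in this test and higher numbers for lower toxicity in this test), compound 1 `COc1nc(-c2cccc(Cl)c2)ccc1[C@@H](c1ccccc1)[C@@](O)(CCN(C)C)c1cccc2ccccc12` gives > 50 ug/mL, which is a limit of the assay rather than a number. Compound 2 `COc1ncc(-c2ccccc2)cc1[C@@H](c1ccccc1)[C@@](O)(CCN(C)C)c1cccc2ccccc12` likewise gives > 50 ug/mL, a limit. Compound 3 `COc1ncc(-c2ccccc2)cc1[C@@H](c1ccccc1)[C@@](O)(CCN(C)C)c1cccc(F)c1F` gives > 50 ug/mL, again a limit. Among the compounds with values here, all three values sit at the same limit (the limit of > 50 ug/mL in this assay, at which 3 of the 3 values shown sit), so the only measured step, a step that the two limits leave unreadable from compound 2 to compound 3, cannot be read, and no measured step bears on the change to compound 4 `COc1nc(-c2ccc(C(F)(F)F)cc2)ccc1[C@@H](c1ccccc1)[C@@](O)(CCN(C)C)c1cccc2ccccc12`, namely (4-(trifluoromethyl)phenyl in place of 3-chlorophenyl on an aromatic carbon). With no readable step, no shift beyond the scatter can be expected in this assay. Given the unreadable step that the two limits leave unreadable from compound 2 to compound 3, compound 4 is expected to show 60 ug/mL, within a range of 35 ug/mL to 150 ug/mL, most probably reported as a limit again. The expected step is thus a step that the limit leaves unreadable from compound 1 to compound 4.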

Compound 4, half-maximal cytotoxic concentration: > 50 ug/mL
Compound 4: a limit, no number (the forecaster's own chance of this, stated with the estimate: 80%); the middle value lies beyond the limit too.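

Compound 1 and compound 4 both give a limit rather than a number, so 4-(trifluoromethyl)phenyl in place of 3-chlorophenyl yields no readable step: the limit of > 50 ug/mL in this assay, at which 4 of the 4 values shown sit.

The compounds shown leave open whether any of them truly differs from another in this assay.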